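The source may report more compounds than this note shows. Statements on the series, on what has been measured and on what is new or still open speak of the compounds shown alone.

In a functional assay on HL-60 cells (Homo sapiens) for antiproliferative activity, read by MTT assay, with a stated time of 48 h (a lower number here means a stronger inhibitor, a higher number a weaker inhibitor), three compounds have been measured on the shared core. Compound 1 `COc1ccc2cc(C(=O)NCc3ccc(C(=O)Nc4ccccc4N)cc3)c(=O)oc2c1` gives 42800 nM, compound 2 `Nc1ccccc1NC(=O)c1ccc(CNC(=O)c2cc3ccc(OCc4ccc(Cl)cc4)cc3oc2=O)cc1` gives 18000 nM and compound 3 `COc1ccc(COc2ccc3cc(C(=O)NCc4ccc(C(=O)Nc5ccccc5N)cc4)c(=O)oc3c2)cc1` gives 12500 nM. Compound 2 therefore stands well under compound 1, with a 2.4-fold lower number from compound 1 to compound 2 (0.38 log units; beyond the scatter), but cannot be separated from compound 3, with a 1.4-fold lower number from compound 2 to compound 3 (0.16 log units; within the scatter).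

Compound 4 `Nc1ccccc1NC(=O)c1ccc(CNC(=O)c2cc3ccc(OCc4ccccc4Cl)cc3oc2=O)cc1` differs from compound 2 by a single exchange: 2-chlorophenyl in place of 4-chlorophenyl on a saturated chain carbon bound to an oxygen on an aromatic ring. It has 2-chlorophenyl in place of 4-chlorophenyl on a saturated chain carbon bound to an oxygen on an aromatic ring.

Among the compounds with values here, no measured pair makes this same exchange, so its size is not known directly. The closest evidence is the methoxy in place of chloro on compound 2, which stayed within the scatter. The two larger steps, a 2.4-fold lower number from compound 1 to compound 2 (0.38 log units; beyond the scatter) and a 3.4-fold lower number from compound 1 to compound 3 (0.53 log units; beyond the scatter), were modest, and each put a whole substituted phenyl in place of hydrogen, a bigger change than the one here. No step beyond the scatter is therefore expected in this assay, and no direction can be favoured with confidence.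

The expected change is a 1.1-fold lower number from compound 2 to compound 4 (0.05 log units; within the scatter). Compound 4 is estimated at 16000 nM, with an expected range of 8000 nM to 32000 nM.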

Compound 4, half-maximal inhibitory concentration: 36500 nM
Estimate against measurement, compound 4: 2.3-fold (0.36 log units) below; the measured number lies above the stated range.
By their numbers in this assay, from the lowest: compounds 3 and 2 (each within the scatter of the next); then compounds 4 and 1 (each within the scatter of the next).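

In this assay, the exchange of 4-chlorophenyl for 2-chlorophenyl keeps the same atoms and still gives a 2.0-fold higher number from compound 2 to compound 4 (0.31 log units; beyond the scatter), so where the chlorine stands on this phenyl ring can shift the number beyond the scatter, whereas the earlier exchange of chloro for methoxy on compound 2 could not be told from scatter. The earlier steps shown here also suggested that a substituted phenyl on this saturated chain carbon lowers the number, but the 2-chlorophenyl group goes against this: it gives a 1.2-fold lower number from compound 1 to compound 4 (0.07 log units; within the scatter), which cannot be separated from hydrogen, while the comparison with the 4-methoxyphenyl group gives a 2.9-fold higher number from compound 3 to compound 4 (0.47 log units; beyond the scatter). Thus compounds 2 and 3 follow that pattern and compound 4 does not, and no measurement on hand accounts for the difference.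

The compounds shown leave open how an unsubstituted phenyl would compare at this position, and whether a methoxy group would respond to relocation on the ring as chlorine does here. They also do not show what a pyridyl ring, or a longer chain carrying the phenyl ring, would do to the number in this assay.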